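This account rests on a few compounds, and the source may have more. Where it says the series, first, only, none or still open, it means among the compounds named here.

Of the compounds shown here, three built on one shared core have been tested in a functional assay on MDA-MB-231 cells (Homo sapiens) for inhibition, read by CellTiter-Glo, with a stated time of 96 h; a lower number here means that less compound is tolerated, a higher number that more compound is tolerated. Compound 2 `CC1=C(C(C)C(=O)N(CCNC(C)C)C(C)C)c2cc(F)ccc2/C1=C\c1ccc([S+](C)[O-])cc1` gives 21300 nM. Compound 3 `CC1=C(C(C)C(=O)NCCN2CCCC2)c2cc(F)ccc2/C1=C\c1ccc([S+](C)[O-])cc1` gives 39300 nM. For compound 1 `CC1=C(C(C)C(=O)N(C)CCN(C)C)c2cc(F)ccc2/C1=C\c1ccc([S+](C)[O-])cc1` this assay reports only a limit, > 50000 nM, which is what the limit of > 50000 nM in this assay, at which 1 of the 3 values shown sits, records. Compound 2 therefore stands together with compound 3: the step of a 1.8-fold higher number from compound 2 to compound 3 (0.27 log units; within the scatter) lies within the scatter, so the two cannot be told apart, while the step of an at least 2.3-fold lower number from compound 1 to compound 2 (0.37 log units; beyond the scatter) is at least modest and the step of an at least 1.2-fold lower number from compound 1 to compound 3 (0.10 log units; that floor lies within the scatter) has a floor inside the scatter.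

Compound 4 `CC1=C(C(C)C(=O)NCCN2CCCCC2)c2cc(F)ccc2/C1=C\c1ccc([S+](C)[O-])cc1` has not yet been measured. It differs from compound 2 in one place: (2-(piperidin-1-yl)ethyl)amino in place of isopropyl(2-(isopropylamino)ethyl)amino on a carbonyl carbon. The measured step that bears on this most closely is the one in which (2-(pyrrolidin-1-yl)ethyl)amino took the place of the same leaving group; because a 1.8-fold higher number from compound 2 to compound 3 (0.27 log units; within the scatter) stayed within the scatter there, a step of a 1.6-fold higher number from compound 2 to compound 4 (0.22 log units; within the scatter) is expected from compound 2 to compound 4 in this assay, again within the scatter. Compound 4 is accordingly estimated to give about 35000 nM, with a range from 15000 nM to 80000 nM.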

Compound 4, half-maximal cytotoxic concentration: 39300 nM
Compound 4: the middle estimate sits 1.1-fold (0.05 log units) below what was measured, within the range that was stated.
By their numbers in this assay, from the lowest: compounds 2, 3 and 4 (each within the scatter of the next). At a limit, above all of these: compound 1.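

In this assay, piperidin-1-yl in place of pyrrolidin-1-yl on the saturated chain carbon, two bonds along the chain from an amide-type nitrogen, gives no change at the digits printed from compound 3 to compound 4 (within the scatter), and (2-(piperidin-1-yl)ethyl)amino in place of the ringless isopropyl(2-(isopropylamino)ethyl)amino on the carbonyl carbon gives a 1.8-fold higher number from compound 2 to compound 4 (0.27 log units; within the scatter), so compounds 2, 3 and 4 cannot be told apart and these two ring amines give the same reading at the digits printed. The comparison with the remaining compound, an at least 1.2-fold lower number from compound 1 to compound 4 (0.10 log units; that floor lies within the scatter), cannot be read as a real difference. Compound 1 is recorded only as a limit: the limit of > 50000 nM in this assay, at which 1 of the 4 values shown sits.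

Three different amine-bearing groups on this carbonyl carbon thus give numbers that stay within the scatter of one another, which leaves open whether any change here can move the number clearly away from these values. A morpholine at the end of the chain, a carboxylic acid in place of the amine, or a longer chain between the amide nitrogen and the ring amine would each be a further test of how much this position matters.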